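The compounds below may be only part of what the source reports. "The series", "measured", "known", "first", "only" and "open" are said of these compounds alone.

Measured so far in a physicochemical assay for solubility, at pH 2; a higher number here means a more soluble compound, a lower number a less soluble compound:
- compound 1 `CNc1nc(NCCN2CCNCC2)c2sc(-c3ccc(C(F)(F)F)cc3)cc2n1` gives 203 ug/mL
- compound 2 `CN(C)CCCNc1nc(N)nc2cc(-c3ccc(C(F)(F)F)cc3)sc12` gives 210 ug/mL
- compound 3 `Nc1nc(NC2CCCNC2)c2sc(-c3ccc(C(F)(F)F)cc3)cc2n1` gives 125 ug/mL

Compound 3 (125 ug/mL) lies within the scatter of both compound 1 and compound 2, so these three values cannot be told apart. Compound 4 `Nc1nc(N2CCC(N)CC2)c2sc(-c3ccc(C(F)(F)F)cc3)cc2n1` has the same atoms as compound 3, joined differently: 4-aminopiperidin-1-yl in place of (piperidin-3-yl)amino on an aromatic carbon on an aromatic carbon next to the ring nitrogen. Among the measured compounds shown here, the only measured step that touches this substituent is a 1.7-fold lower number from compound 2 to compound 3 (0.23 log units; within the scatter) and it stays within the scatter. For the measured compounds named here, that step is a different exchange, and no measured pair shows the present one directly. No step beyond the scatter is therefore expected in this assay for this change. The estimated move is a 1.1-fold higher number from compound 3 to compound 4 (0.05 log units; within the scatter) with no clear direction expected. For compound 4 the estimated value is 140 ug/mL with an expected range from 70 ug/mL to 260 ug/mL in this measurement.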

Compound 4, solubility: 134 ug/mL
Estimate against measurement, compound 4: 1.0-fold (0.02 log units) above; the range from low to high includes it.
By their numbers in this assay, from the lowest: compounds 3, 4, 1 and 2 (each within the scatter of the next).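

In this assay, among the compounds shown here, the first direct exchange of (piperidin-3-yl)amino for 4-aminopiperidin-1-yl on this aromatic carbon, with the same atoms joined differently and one hydrogen-bond donor fewer under the count, gives no separable step (a 1.1-fold higher number from compound 3 to compound 4 (0.03 log units; within the scatter)). Set against the open-chain (3-(dimethylamino)propyl)amino, the same group also stays inside the noise (a 1.6-fold lower number from compound 2 to compound 4 (0.20 log units; within the scatter)), so at this position neither the ring in place of the chain nor the way the ring is attached registers as a difference in this measurement. No accompanying data bear on these results.

Every substituent shown at this aromatic carbon still carries a further amine nitrogen, so the measured range says nothing about a group without one. A morpholin-4-yl or a carboxylic acid at this position remains the open comparison for whether any step beyond the scatter exists here.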